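A few compounds are considered here, and "the series" means these few. Any claim that something is new, unique, unknown or untested is made for them only; others in the source may bear on it.

Compound 1 `COc1ccccc1N1CCN(CCCNC(=O)Cc2c[nH]c3ccccc23)CC1` gives the tightest number of the three measured compounds in an assay on isolated protein (thoracic aorta, strain Sprague-Dawley) for antagonist activity at Alpha-1D adrenergic receptor (Rattus norvegicus), with a stated time of 20 min (on this read-out lower numbers stand for tighter binding and higher numbers for weaker binding), at 5.25 nM. Compound 2 `COc1ccccc1N1CCN(CCCNC(=O)CCc2c[nH]c3ccccc23)CC1` gives 34.7 nM, and compound 3 `COc1ccccc1N1CCN(CCCNC(=O)c2cc3cc(O)ccc3[nH]2)CC1` gives 26.9 nM. Compound 4 `COc1ccccc1N1CCN(CCCNC(=O)c2cn(C)c3ccccc23)CC1` differs from compound 1 by 1-methyl-1H-indol-3-yl in place of (1H-indol-3-yl)methyl on a carbonyl carbon. Among the measured compounds shown here, two measured steps bear on this change, each altering the group attached to the same carbonyl carbon: a 6.6-fold higher number from compound 1 to compound 2 (0.82 log units; beyond the scatter), and a 5.1-fold higher number from compound 1 to compound 3 (0.71 log units; beyond the scatter). Both of those changes weakened binding, and the change made in compound 4 is expected to weaken binding as well, by a modest step, a 3.8-fold higher number from compound 1 to compound 4 (0.58 log units; beyond the scatter). Compound 4 is therefore estimated to reach 20 nM in this assay, with a range from 5 nM to 80 nM.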

Compound 4, dissociation constant: 5.5 nM
For compound 4 the middle estimate is 3.6-fold (0.56 log units) above the measured one; the measured number falls inside the stated range.
By their numbers in this assay, from the lowest: compounds 1 and 4 (each within the scatter of the next); then compounds 3 and 2 (each within the scatter of the next).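

Unlike the two earlier changes at this carbonyl carbon, this one leaves the number within the scatter, with a 1.0-fold higher number from compound 1 to compound 4 (0.02 log units; within the scatter) in this assay, even though the hydrogen-bond donor counted in (1H-indol-3-yl)methyl is absent from 1-methyl-1H-indol-3-yl. The group on this carbon can still matter, with a 4.9-fold lower number from compound 3 to compound 4 (0.69 log units; beyond the scatter) beyond the scatter. Nothing given here explains either result.

Still open, as far as these compounds go, is how 1-ethyl-1H-indol-3-yl or plain 1H-indol-3-yl on this carbonyl carbon would compare with 1-methyl-1H-indol-3-yl in this assay here.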